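The source may hold more compounds than are shown below. What is called first, only, known or untested is meant among the compounds shown, and "the series" means these compounds.

Three compounds were measured in an ADME assay on the whole organism with Oryza sativa as the target, tested at 1 uM; a lower number here means a stronger effect, a higher number a weaker effect of the compound at the concentration tested:

compound 1 `CC(C)c1ccccc1NC(=O)N[C@H](C)c1ccccc1`, giving 101%
compound 2 `CC(C)c1ccccc1NC(=O)N[C@@H](C)c1ccccc1`, giving 96%
compound 3 `C[C@@H](NC(=O)Nc1cccc(C(F)(F)F)c1)c1ccccc1`, giving 72%

Compound 1 stands at the highest number of the three, so its effect in this assay is the weakest of those shown. Compound 2 is its closest neighbour; the step of a number 5 percentage points lower from compound 1 to compound 2 (within the scatter) rests on (the fact that compounds 1 and 2 differ only in the configuration as drawn). Within the data shown here, compound 3 lies furthest away, and its value is beyond the scatter from that of compound 1, but no single-point step connects the two.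

Compound 4 `C[C@@H](NC(=O)Nc1ccccc1F)c1ccccc1` has not yet been measured. It differs from compound 1 by fluoro in place of isopropyl on an aromatic carbon. None of the measured steps bears directly on this exchange: the only step within the scatter concerns configuration alone, and the other aryl substitution pattern shown, in compound 3, changes more than one thing at once. Compound 4 is therefore expected to sit near compound 1, with some allowance for a lower number in this assay; the step of a number 11 percentage points lower from compound 1 to compound 4 (beyond the scatter) is estimated to lie at the edge of the scatter. For compound 4 the expected value is 90%, with a range from 70% to 105%.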

Compound 4, a percentage reported as activity, at one concentration (the size of the read-out at that concentration, not a potency): 95%
Beside the measured number, compound 4's estimate is 5 percentage points below it, within the range that was stated.
By their numbers in this assay, from the lowest: compound 3; then compounds 4, 2 and 1 (each within the scatter of the next).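

In this assay, the exchange of isopropyl for fluoro on an aromatic carbon, ortho to a large group, is the only step among these compounds that touches this position, and it comes to a number 6 percentage points lower from compound 1 to compound 4 (within the scatter). Among these compounds, the earlier compounds offered a step in configuration alone, so this is the first reading of what a change of substituent at this place does, and the read-out does not separate the two groups at the concentration tested, even though the isopropyl group has more heavy atoms than the single fluorine that enters. Nothing measured in these compounds speaks to why the two groups read alike here.

The compounds shown leave open whether a group of another kind at this place, such as an amine, a carboxylic acid or a longer chain, would give a number beyond the scatter of compound 1. Among the compounds shown here, they also leave open how compound 3, at 72%, relates to the others, as no single-place step connects it to any of them.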